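Swapping a sulfur-linked ethyl chain for an oxygen-linked one

This account rests on a few compounds, and the source may have more. Where it says the series, first, only, none or still open, it means among the compounds named here.

Of the compounds shown here, three sharing a five-membered aromatic core have been tested in a functional assay on the whole organism (strain NMRI) with Mus musculus as the target, with a stated time of 60 min, at a dose of 5 mg/kg by the intraperitoneal route; a lower number here means a weaker effect, a higher number a stronger effect of the compound at the dose given. Compound 1, `CCSc1nnc(Cc2ccccc2Oc2ccccc2)[nH]1`, gives 132% in this assay. Compound 2, `CCCSc1nnc(Cc2ccc(Cl)cc2Oc2ccccc2F)[nH]1`, gives 119%, and compound 3, `Nc1nnc(Cc2ccc(Cl)cc2Oc2ccccc2F)o1`, gives 112%. Among these three numbers compound 1 stands highest: compound 2 is the nearest, and its number lies lower than that of compound 1 by more than the usual scatter; compound 3 is the furthest, also lower by more than the scatter. On these numbers compound 1 is therefore the most active of the three.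

Compound 4, `CCOc1nnc(Cc2ccccc2Oc2ccccc2)[nH]1`, has not yet been measured. It differs from compound 1 in one place: ethoxy in place of ethylsulfanyl on an aromatic carbon. The sulfur atom that ties the chain to the core is thus replaced by an oxygen atom, while the chain itself keeps its length. Within the data shown here, no measured pair in this set shows what such a swap does in this assay, so the expectation rests on compound 1 alone. The step estimated here, a number 10 percentage points lower from compound 1 to compound 4 (within the scatter), is expected to stay within the usual scatter, with a slight lean downward. Compound 4 is therefore expected to give about 122%, with a plausible range from 95% to 148%.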

Compound 4, a percentage reported as activity, at one dose (the size of the read-out at that dose, not a potency): 123%
Estimate against measurement, compound 4: 1 percentage points below, within the range that was stated.
By their numbers in this assay, from the lowest: compounds 3, 2, 4 and 1 (each within the scatter of the next, the first and the last beyond it).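

In this assay, among these compounds, the exchange of ethylsulfanyl for ethoxy gives a number 9 percentage points lower from compound 1 to compound 4 (within the scatter) and is the only change in this set that can be read on its own, since the earlier compounds differ from one another in more than one place. It shows that, on this aromatic carbon between two ring nitrogen atoms, the sulfur atom linking the chain to the core can give way to an oxygen atom, with the chain otherwise unchanged, and the read-out at this single dose stays within the usual scatter. Nothing at hand explains why the two compounds read so alike.

This single pair leaves open whether the same exchange would read the same way on the chlorine- and fluorine-bearing compound 2, where the sulfur atom carries a longer chain. It also leaves open how far this position tolerates groups of a different kind, such as a butoxy chain or a carboxylic acid, since ethoxy and ethylsulfanyl have the same number of heavy atoms and neither carries a ring or a net charge.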